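The source may hold more compounds than are shown below. What is called first, only, known or untested is meant among the compounds shown, and "the series" means these compounds.

Working notes on the series. Three compounds have been run through a functional assay on SK-OV-3 cells (Homo sapiens) for cytotoxicity, read by sulforhodamine B assay, with a stated time of 48 h; a lower number here means a stronger inhibitor of growth, a higher number a weaker inhibitor of growth. Compound 1 `ClCc1ccc(Cn2cnc3c(Cl)ncnc32)cc1` gives 3380 nM. Compound 2 `ClCc1ccc(Cn2cnc3nc(Cl)nc(Cl)c32)cc1` gives 2340 nM. Compound 3 `ClCc1ccc(Cn2cnc3c(Cl)nc(Cl)nc32)cc1` gives 13500 nM. Compound 2 has the lowest number of the three, though its gap to compound 1 lies within the scatter and only its gap to compound 3 lies beyond it.

One change has been followed directly: from compound 3 to compound 1, (hydrogen in place of chloro on an aromatic carbon), the result was a 4.0-fold lower number from compound 3 to compound 1 (0.60 log units; beyond the scatter). Compound 2 and compound 3 carry the same atoms joined differently; how the two cores differ is not broken down here.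

Compound 4 `ClCc1ccc(Cn2cnc3ncnc(Cl)c32)cc1` is still to be measured in this assay. It relates to compound 2 as compound 1 relates to compound 3: hydrogen in place of chloro on an aromatic carbon. The surroundings of the place are described in the same words for both pairs, so it is the same change on a different core. Among the compounds with values here, the expectation for compound 4 is a step of about a 3.3-fold lower number from compound 2 to compound 4 (0.52 log units; beyond the scatter) because a 4.0-fold lower number from compound 3 to compound 1 (0.60 log units; beyond the scatter) is the only precedent, read with some caution as a single instance. Compound 4 is therefore estimated at 700 nM, with a range from 250 nM to 2000 nM.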

Compound 4, concentration for 50% growth inhibition: 11200 nM
Estimate against measurement, compound 4: 16-fold (1.20 log units) below; the measured number lies above the stated range.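

In this assay, putting hydrogen in place of chloro on the aromatic carbon between two ring nitrogen atoms gives a 4.8-fold higher number from compound 2 to compound 4 (0.68 log units; beyond the scatter), which runs opposite to the earlier step on the other core: the same change on two cores in this assay, a 4.0-fold lower number (0.60 log units; beyond the scatter) from compound 3 to compound 1 and a 4.8-fold higher number (0.68 log units; beyond the scatter) from compound 2 to compound 4, 19-fold (1.28 log units) apart, beyond the scatter of two such steps

The change therefore does not carry from one core to the other in these compounds, and the precedent from the first pair cannot be used to predict its direction in the second. What this does not show is why the two cores part, or how the change would run on any further core, since the comparison rests on a single pair of compounds for each core and on one cell line.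

Going by these compounds, it remains open whether an amine or a methoxy group on the same aromatic carbon would follow the hydrogen or the chloro compounds on either core. Also open, on these data alone, is whether the opposite steps would persist with a hydroxymethyl group in place of the chloromethyl group.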